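The compounds below may be only part of what the source reports. "The series", "measured", "known", "first", "only" and "open" are said of these compounds alone.

In an ADME assay on MCF7-DOX cells (Homo sapiens) for cytotoxicity, read by MTT assay, with a stated time of 48 h (on this read-out higher numbers stand for weaker inhibition and lower numbers for stronger inhibition), compound 1 `COc1cccc(/C=C/C(=O)c2c(OC)cc(OC)c(CC=C(C)C)c2O)c1` gives 49200 nM and compound 2 `COc1cc(OC)c(C(=O)/C=C/c2cccc(C(F)(F)F)c2)c(O)c1CC=C(C)C` gives 66600 nM while compound 3 `COc1ccc(/C=C/C(=O)c2c(OC)cc(OC)c(CC=C(C)C)c2O)cc1` gives 46900 nM and so stands within the scatter of both. Compound 4 `COc1cc(OC)c(C(=O)/C=C/c2ccc(N(C)C)cc2)c(O)c1CC=C(C)C` has not been measured yet and carries dimethylamino in place of methoxy on an aromatic carbon. The closest evidence is 4-methoxyphenyl in place of 3-methoxyphenyl (a 1.0-fold lower number from compound 1 to compound 3 (0.02 log units; within the scatter)), then 4-methoxyphenyl in place of 3-(trifluoromethyl)phenyl (a 1.4-fold lower number from compound 2 to compound 3 (0.15 log units; within the scatter)), and trifluoromethyl in place of methoxy (a 1.4-fold higher number from compound 1 to compound 2 (0.13 log units; within the scatter)). All three steps stayed within the scatter, though none involves dimethylamino. No step beyond the scatter, in either direction, is therefore expected in this assay (a 1.2-fold lower number from compound 3 to compound 4 (0.07 log units; within the scatter)). Compound 4 is estimated at 40000 nM (expected range 16000 nM to 80000 nM).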

Compound 4, half-maximal inhibitory concentration: > 100000 nM
Compound 4 ended at the assay's limit; the forecaster's own chance of this, stated with the estimate: 10%; middle value at least 2.5-fold (0.39 log units) from the limit.
By their numbers in this assay, from the lowest: compounds 3, 1 and 2 (each within the scatter of the next). At a limit, above all of these: compound 4.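

In this assay, among these compounds, swapping methoxy for dimethylamino on the aromatic carbon para to a large group gives the first step to pass the scatter: an at least 2.1-fold higher number from compound 3 to compound 4 (0.32 log units; beyond the scatter). The two other new steps, an at least 2.0-fold higher number from compound 1 to compound 4 (0.30 log units; that floor lies within the scatter) and an at least 1.5-fold higher number from compound 2 to compound 4 (0.17 log units; that floor lies within the scatter), have floors within the scatter, so they set compound 4 clearly apart from neither compound 1 nor compound 2. The value of compound 4 is a limit, not a number: the limit of > 100000 nM in this assay, at which 1 of the 4 values shown sits.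

As far as these compounds go, how far compound 4 lies past that limit remains open. Also open, from the compounds shown here alone, is whether a primary amine or a morpholine at this place would match methoxy or dimethylamino.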